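The compounds below may be only part of what the source reports. "The series", "measured", "known", "first", "only" and "open" are said of these compounds alone.

Of the compounds shown here, three built on one shared core have been tested in an ADME assay on HEK293 cells (Homo sapiens) for cytotoxicity, read by CellTiter-Glo and resazurin assay, with a stated time of 72 h; on this read-out lower numbers stand for an effect already at smaller amounts and higher numbers for an effect only at larger amounts of compound. Compound 1 `CC(C)N(Cc1cccc(OCCCCCC(=O)O)c1)C(=O)c1ccccc1` carries hydrogen on an aromatic carbon where compound 2 `CC(C)Oc1cccc(-c2ccc(C(=O)N(Cc3cccc(OCCCCCC(=O)O)c3)C(C)C)cc2)c1` carries 3-isopropoxyphenyl, and compound 3 `CCOC(=O)CCCCCOc1cccc(CN(C(=O)c2ccc(-c3cccc(OC(C)C)c3)cc2)C(C)C)c1` carries ethyl where compound 2 carries hydrogen. In this assay compound 1 gives only a limit of > 26000 nM. In this assay compound 2 likewise gives only a limit, > 26000 nM. In this assay compound 3 also gives only a limit, > 26000 nM. Compound 3 therefore stands together with the other two at the limit of > 26000 nM in this assay, at which 3 of the 3 values shown sit, and neither a step that the two limits leave unreadable from compound 1 to compound 2 nor a step that the two limits leave unreadable from compound 2 to compound 3 can be given a size. Compound 4 `CCOC(=O)CCCCCOc1cccc(CN(C(=O)c2ccc(-c3cccc(S(C)(=O)=O)c3)cc2)C(C)C)c1` differs from compound 3 by methylsulfonyl in place of isopropoxy on an aromatic carbon. Among the compounds with values here, no measured step bears directly on this change, and the two steps that exist are unreadable, so no step beyond the scatter is expected. The estimated step is a step that the limit leaves unreadable from compound 3 to compound 4. Compound 4 is expected to give about 30000 nM in this assay, between 10000 nM and 90000 nM, most probably once more only a limit.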

Compound 4, half-maximal effective concentration: > 26000 nM
Compound 4 gave a limit, no number; the forecaster's own chance of this, stated with the estimate: 85%; the middle value is on the limit's open side.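

In this assay, within the data shown here, compound 3 and compound 4 both give only a limit and no number, so no step between them can be read. The four compounds shown leave open at what concentration any of them would harm these cells, and whether methylsulfonyl in place of isopropoxy changes that.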